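Ring nitrogen added and isopropyl swapped in on the shared core

The source may hold more compounds than are shown below. What is called first, only, known or untested is meant among the compounds shown, and "the series" means these compounds.

Measured compounds:
compound 1, `CN(C)C(=O)CN1CCC(c2cc3c(-c4ccc(=O)n(C5CCC5)c4)ccnc3[nH]2)CC1`, < 3 uL/min 
compound 2, `CN(C)C(=O)CN1CCC(c2cc3c(-c4ccc(=O)n(C)c4)ccnc3[nH]2)CC1`, < 3 uL/min 
compound 3, `CC(C)Cn1cc(-c2ccnc3[nH]c(C4CCN(CC(=O)N(C)C)CC4)cc23)ccc1=O`, 21 uL/min 

Compound 2 stands at a limit of an ADME assay on microsomes from liver (Homo sapiens) for metabolic stability; on this read-out lower numbers stand for slow clearance and higher numbers for fast clearance: its value of < 3 uL/min is a limit rather than a number. Compound 1 also sits at a limit, which is why the step that the two limits leave unreadable from compound 1 to compound 2 cannot be read (the limit of < 3 uL/min in this assay, at which 2 of the 3 values shown sit). Going by the values given here, compound 3 is the only one with a readable number, and the step of an at least 7.0-fold higher number from compound 2 to compound 3 (0.84 log units; beyond the scatter) shows what a larger alkyl group on the aromatic nitrogen did; the step of an at least 7.0-fold higher number from compound 1 to compound 3 (0.84 log units; beyond the scatter) points the same way.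

Compound 4, `CC(C)n1cc(-c2ccnc3[nH]c(C4CCN(CC(=O)N(C)C)CC4)cc23)cnc1=O`, is not yet measured. It differs from compound 2 thus: a group of 10 heavy atoms (7 carbon, 2 nitrogen, 1 oxygen; one six-membered aromatic ring with 2 hetero atoms) in place of a group of 8 heavy atoms (6 carbon, 1 nitrogen, 1 oxygen; one six-membered aromatic ring with 1 hetero atom), on an aromatic carbon. This change does two things at once, replacing the methyl on the aromatic nitrogen with a larger group and inserting a second hetero atom into the six-membered aromatic ring. Among the compounds with values here, no measured step covers that ring change, so only the alkyl enlargement has a precedent, in compound 3.

Compound 4 is therefore expected to move upward, an at least 2.0-fold higher number from compound 2 to compound 4 (0.30 log units; that floor lies within the scatter), but less far than compound 3 went. The estimate for compound 4 in this assay is 6 uL/min, within 3 uL/min to 15 uL/min.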

Compound 4, intrinsic clearance in a liver preparation (reported as CLH), per the amount of preparation that the assay uses: 24 uL/min
For compound 4 the middle estimate is 4.0-fold (0.60 log units) below the measured one, and the stated range ends below it.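

In this assay, the exchange on the aromatic carbon opposite the ring nitrogen gives an at least 8.0-fold higher number from compound 2 to compound 4 (0.90 log units; beyond the scatter). Going by these compounds alone, this is the first sign that this position tolerates no free swap of the group with one hetero atom in its six-membered aromatic ring for the group with two: the earlier steps changed only the alkyl group on the aromatic nitrogen and left that ring as it was, whereas compound 4 carries the ring with 2 hetero atoms and an isopropyl together and still leaves the limit for a readable number. Compound 2 sits at a limit, and the step from it can be read only as a floor, not as a full size: the limit of < 3 uL/min in this assay, at which 2 of the 4 values shown sit.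

Which part of the exchange carries the step stays open, the second ring nitrogen or the isopropyl on the aromatic nitrogen, and a methyl on the ring with 2 hetero atoms would separate the two. Also open, going by these compounds, is how an ethyl or a hydroxyethyl chain on that aromatic nitrogen would read in this assay, on either ring.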